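The source may hold more compounds than are shown below. What is called first, only, known or untested is meant among the compounds shown, and "the series" means these compounds.

Series notes, sulfonamide core set, an in vitro ADME assay on microsomes from liver (Homo sapiens) for metabolic stability (on this read-out lower numbers stand for a shorter-lived compound and higher numbers for a longer-lived compound), read-out.

Compound 1 `C[C@@H](c1ccc(Cl)cc1)N1Cc2cncn2C(CC2(C)COC2)S1(=O)=O` gives 1.27 h in this assay. Compound 2 `COC(C)(C)CC1n2cncc2CN([C@@H](C)c2ccc(Cl)cc2)S1(=O)=O` gives 0.2 h. Compound 3 `CC(C)CC1n2cncc2CN([C@@H](C)c2ccc(Cl)cc2)S1(=O)=O` gives 0.1 h, the lowest of the three numbers; its gap to compound 2 is within the scatter, while the gap to compound 1 is beyond it, as a 13-fold lower number from compound 1 to compound 3 (1.10 log units; beyond the scatter) shows.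

Compound 4 `C[C@@H](c1ccc(Cl)cc1)N1Cc2cncn2C(C[C@@H](O)c2ccccc2)S1(=O)=O` is not yet measured. It differs from compound 3 by hydroxy(phenyl)methyl in place of isopropyl on a saturated chain carbon bound to a saturated ring carbon.

Steps bearing on this position: a 13-fold lower number from compound 1 to compound 3 (1.10 log units; beyond the scatter) and a 6.4-fold lower number from compound 1 to compound 2 (0.80 log units; beyond the scatter), both beyond the scatter, show that the two oxygen-bearing groups measured at this chain carbon gave higher numbers than isopropyl, with the 3-methyloxetan-3-yl case larger. The step of a 2.0-fold lower number from compound 2 to compound 3 (0.30 log units; within the scatter), adding methoxy in place of hydrogen, stayed within the scatter. Among the measured compounds shown here, no measured compound carries a hydroxy or a phenyl at this place, so the weight of the entering hydroxy(phenyl)methyl group is untested. Given that an oxygen-bearing group here has so far moved the number upward, a modest upward step is expected for compound 4, around a 3.0-fold higher number from compound 3 to compound 4 (0.48 log units; beyond the scatter), with wide uncertainty. Compound 4 is therefore estimated at 0.3 h, range 0.08 h to 1.2 h.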

Compound 4, half-life: 0.4 h
The estimate for compound 4 lay 1.3-fold (0.12 log units) below the measured number, and the stated range covers the measured number.
By their numbers in this assay, from the lowest: compounds 3, 2 and 4 (each within the scatter of the next, the first and the last beyond it); then compound 1.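

In this assay, among the compounds shown here, hydroxy(phenyl)methyl is the first group at this place to bring in a six-membered aromatic ring of carbon only and a hydrogen-bond donor, and it ends beyond the scatter of the isopropyl case (with a 4.0-fold higher number from compound 3 to compound 4 (0.60 log units; beyond the scatter)). Set against the 1-methoxy-1-methylethyl case, the change stays within the scatter (with a 2.0-fold higher number from compound 2 to compound 4 (0.30 log units; within the scatter)), so the oxygen-bearing group with the ring and the open-chain ether cannot be told apart here, while the 3-methyloxetan-3-yl case keeps the highest number of the four, beyond the scatter of the entering group (with a 3.2-fold lower number from compound 1 to compound 4 (0.50 log units; beyond the scatter)). The data at hand offer no explanation for any of these steps.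

Hydroxy and phenyl enter together in compound 4, so the share of each remains unresolved: a plain phenyl or benzyl group on this chain carbon, or a hydroxy on an open alkyl chain such as 1-hydroxy-1-methylethyl, would separate them. Also open, as far as these compounds go, are the opposite configuration at the defined stereocentre and how an amine or a carboxylic acid at this place would read.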